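This account rests on a few compounds, and the source may have more. Where it says the series, first, only, none or still open, it means among the compounds named here.

In a functional assay on M21 cells (Homo sapiens) for antiproliferative activity, read by sulforhodamine B assay, with a stated time of 48 h (on this read-out higher numbers stand for weaker inhibition and lower numbers for stronger inhibition), compound 1 `CC(C)(C)c1ccc(NS(=O)(=O)c2ccc(N3CCNC3=O)cc2)cc1` gives > 1000 nM as a limit and not a number. Among the measured compounds shown here, compound 2 `CCCCCc1ccc(NS(=O)(=O)c2ccc(N3CCNC3=O)cc2)cc1` carries pentyl in place of tert-butyl on an aromatic carbon and gives 870 nM as the only true number so far, which makes it the one firm reference point for what follows. Compound 3 `CCCCCCOc1ccc(NS(=O)(=O)c2ccc(N3CCNC3=O)cc2)cc1` has not yet been measured and changes the same place again, with hexyloxy in place of pentyl on an aromatic carbon while the rest of the molecule stays the same. For the measured compounds named here, the only measured step that bears on this change is an at least 1.1-fold lower number from compound 1 to compound 2 (0.06 log units; that floor lies within the scatter) and it involves a different swap, so it offers no firm size or direction to carry over. Starting from compound 2 at 870 nM no shift beyond the scatter is expected in this assay and neither direction is clearly favoured. The expected change on this estimate is a 1.2-fold lower number from compound 2 to compound 3 (0.09 log units; within the scatter) and it is a small one. Compound 3 is expected at 700 nM within an estimated range of 250 nM to 2000 nM for now.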

Compound 3, half-maximal inhibitory concentration: > 1000 nM
Compound 3 ended at the assay's limit; the forecaster's own chance of this, stated with the estimate: 25%; middle value at least 1.4-fold (0.15 log units) away from the limit.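

In this assay, hexyloxy in place of pentyl gives an at least 1.1-fold higher number from compound 2 to compound 3 (0.06 log units; that floor lies within the scatter), so exchanging the pentyl chain for a longer chain joined through an oxygen brings no visible gain in inhibition at this place. Of the three groups shown here, only pentyl gives a true number, but this does not make it a clear winner, as the step from compound 2 to compound 3 stays within the usual scatter and the step between compound 1 and compound 3 cannot be read. What this position can reveal so far is therefore capped by a single boundary, and the groups cannot be put in a firm order against it: the limit of > 1000 nM in this assay, at which 2 of the 3 values shown sit.

The compounds shown leave open whether the oxygen or the chain length matters in hexyloxy, which a plain hexyl chain or a pentyloxy group would help to separate. As far as these compounds go, it also remains open whether a quite different group at this place, such as an amine or a carboxylic acid, would bring the number clearly lower.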